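Trifluoromethylphenyl in place of fluorophenyl on a tetrazole-bearing scaffold

The source may hold more compounds than are shown below. What is called first, only, known or untested is meant among the compounds shown, and "the series" means these compounds.

Compound 1 `O=C(Cn1nnc(-c2ccccc2)n1)Nc1ccccn1` is described only as "not active" (no number reported) in an assay on HEK293 cells for activation of Kir3.1/Kir3.2 (Homo sapiens), read by thallium flux (a lower number here means a smaller maximal response, a higher number a larger maximal response), with no number given. Compound 2 `Cc1cc(NC(=O)Cn2nnc(-c3cccc(F)c3)n2)n(C2CCCCC2)n1` gives 96% in this assay, the only number shown, so it stands alone among the compounds measured. Compound 3 `Cc1cc(NC(=O)Cn2nnc(-c3ccc(C(F)(F)F)cc3)n2)n(C2CCCCC2)n1` differs from compound 2 in one place: 4-(trifluoromethyl)phenyl in place of 3-fluorophenyl on an aromatic carbon. Among the compounds with values here, no step between measured compounds is available to guide expectations for this change. In this assay compound 3 is expected to give 85%, with a range from 55% to 105%. The estimated step of a number 11 percentage points lower from compound 2 to compound 3 (beyond the scatter) is expected to be a modest downward one, possibly within the usual scatter.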

Compound 3, largest response reached (Emax), in percent of the reference or control that the assay uses: 94%
Compound 3: middle estimate off by 9 percentage points, on the low side; the measured number falls inside the stated range.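

In this assay, the step of a number 2 percentage points lower from compound 2 to compound 3 (within the scatter) shows that this carbon of the tetrazole carries 4-(trifluoromethyl)phenyl as well as 3-fluorophenyl without a change in maximal response beyond the scatter. The larger group is therefore accepted here on the cyclohexyl-bearing scaffold. Nothing available explains this result.

The step changes both the substituent and its place on the phenyl ring, and 3-(trifluoromethyl)phenyl or 4-fluorophenyl would be needed to separate the two. As far as these compounds go, whether an amine or a carboxylic acid on that ring keeps the response also stays open.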